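Carbamoyl for fluoro on the benzyl arm: solubility

The source may hold more compounds than are shown below. What is called first, only, known or untested is meant among the compounds shown, and "the series" means these compounds.

Measured so far:
compound 1, `COC(=O)c1nc(C)c2c(c1N)C(=O)N(Cc1ccccc1)C2=O`: 7400 nM in a physicochemical assay for solubility, using the shake flask method, in simulated intestinal fluid, measured as kinetic solubility, with a stated time of 2 h, at 25 degrees C, at pH 6.5; a higher number here means a more soluble compound, a lower number a less soluble compound
compound 2, `Cc1noc(-c2nc(C)c3c(c2N)C(=O)N(Cc2ccc(F)cc2)C3=O)n1`: < 5000 nM in this assay

For the measured compounds named here, compound 1 is the only member of the pair with a numerical result, and in this assay compound 1 gives 7400 nM. For compound 2 the result in this assay is a limit, not a number: compound 2 gives < 5000 nM. Going by the values given here, compound 2 therefore stands at the limit of < 5000 nM in this assay, at which 1 of the 2 values shown sits, and the gap between the two measured compounds cannot be sized from what is in hand; they differ in more than one place and no single step connects them.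

The next compound, compound 3, `Cc1noc(-c2nc(C)c3c(c2N)C(=O)N(Cc2ccc(C(N)=O)cc2)C3=O)n1`, is obtained from compound 2 by carbamoyl in place of fluoro on an aromatic carbon, para to a large group, which reads as 4-fluorophenyl to 4-carbamoylphenyl one bond further out.

Among the compounds with values here, no measured step fixes what this exchange does in this assay. The expectation is an upward move, an at least 2.4-fold higher number from compound 2 to compound 3 (0.38 log units; beyond the scatter), beyond the scatter, with the chance that compound 3 also stays at the limit left open. Compound 3 is estimated at 12000 nM, within 3000 nM to 50000 nM.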

Compound 3, solubility: < 5000 nM
Compound 3 ended at the assay's limit; the forecaster's own chance of this, stated with the estimate: 30%; middle value at least 2.4-fold (0.38 log units) away from the limit.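

For the compounds shown here, compound 2 and compound 3 both return a limit rather than a number, and no step between them can be read in this assay: the limit of < 5000 nM in this assay, at which 2 of the 3 values shown sit. Still open, going by these compounds, is how far each of the two compounds lies from that limit, and with it what carbamoyl in place of fluoro does to the read-out.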